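Working notes from compound 3 to compound 4

A few compounds are considered here, and "the series" means these few. Any claim that something is new, unique, unknown or untested is made for them only; others in the source may bear on it.

Measured so far in a functional assay on MCF7 cells (Homo sapiens) for antiproliferative activity, read by MTT assay, with a stated time of 72 h; a lower number here means a stronger inhibitor, a higher number a weaker inhibitor (compound, structure, value):
Compound 1 `COc1cc(/C=C/c2ccc(C3=C(c4ccc(O)cc4)C4CC(S(=O)(=O)Oc5cccc(OC)c5)C3O4)cc2)cc(OC)c1` gives 77100 nM
Compound 2 `O=S(=O)(Oc1ccc(Br)cc1)C1CC2OC1C(c1ccc(/C=C/c3cc(O)cc(O)c3)cc1)=C2c1ccc(O)cc1` gives 16900 nM
Compound 3 `O=S(=O)(Oc1cccc(C(F)(F)F)c1)C1CC2OC1C(c1ccc(/C=C/c3cc(O)cc(O)c3)cc1)=C2c1ccc(O)cc1` gives 11500 nM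

Compound 3 lies within the scatter of compound 2 and clearly lower than compound 1. The change from compound 3 to compound 4 `Cc1ccc(OS(=O)(=O)C2CC3OC2C(c2ccc(/C=C/c4cc(O)cc(O)c4)cc2)=C3c2ccc(O)cc2)cc1` is 4-methylphenyl in place of 3-(trifluoromethyl)phenyl on an oxygen. The rest of the structure stays the same.

For the measured compounds named here, only one measured step bears on this change. It is the exchange of 4-bromophenyl for 3-(trifluoromethyl)phenyl on the same oxygen (a 1.5-fold lower number from compound 2 to compound 3 (0.17 log units; within the scatter)), and it stayed within the scatter. Going by the values given here, no single-place step links compound 1 to the others, so compound 1 gives no direct guide. One step is thin evidence, and the series holds no measured case of 4-methylphenyl on this oxygen.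

On that basis, no shift beyond the scatter is expected in this assay and neither direction is favoured. The expected size of the change is small (a 1.2-fold higher number from compound 3 to compound 4 (0.09 log units; within the scatter)). Estimated for compound 4: 14000 nM (expected range 7000 nM to 30000 nM).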

Compound 4, half-maximal inhibitory concentration: 9200 nM
Compound 4: the middle estimate sits 1.5-fold (0.18 log units) above what was measured; measured number inside the range.
By their numbers in this assay, from the lowest: compounds 4, 3 and 2 (each within the scatter of the next); then compound 1.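

In this assay the exchange of 3-(trifluoromethyl)phenyl for 4-methylphenyl on the oxygen bound to the sulfonyl sulfur gives a 1.3-fold lower number from compound 3 to compound 4 (0.10 log units; within the scatter) and so leaves the number unmoved beyond the scatter, even with 10 heavy atoms leaving and 7 entering. Methyl in place of bromo on an aromatic carbon gives a 1.8-fold lower number from compound 2 to compound 4 (0.26 log units; within the scatter) and adds the first comparison in which only that substituent changes, so this position now has three aryl groups that cannot be told apart in this assay. No supporting measurement is available to explain this flat result.

Compound 1 differs from compounds 2, 3 and 4 in more than one place, so its aryl group cannot be judged separately from the rest of its structure. Still open, from the compounds shown here alone, is whether an amine or a carboxylic acid on this aromatic ring, or a longer alkyl chain in place of the ring, would move the number beyond the scatter.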